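The source may hold more compounds than are shown below. What is called first, only, known or untested is meant among the compounds shown, and "the series" means these compounds.

Compound 1 `O=C(Nc1ccc([N+](=O)[O-])cc1)c1cc(Cl)ccc1O` gives 6.4 ug/mL in a physicochemical assay for solubility; on this read-out lower numbers stand for lower solubility and higher numbers for higher solubility. For compound 2 `O=C(Nc1ccc(C(F)(F)F)cc1)c1cc(Cl)ccc1O` this assay reports only a limit, < 1 ug/mL. Between the two stands a single change, (nitro in place of trifluoromethyl on an aromatic carbon), and it brings an at least 6.4-fold higher number from compound 2 to compound 1 (0.80 log units; beyond the scatter). Compound 3 `O=C(Nc1ccc(C(F)(F)F)c(Cl)c1)c1cc(Br)ccc1O` likewise sits at a limit in this assay, < 1 ug/mL, namely (the limit of < 1 ug/mL in this assay, at which 2 of the 3 values shown sit). How the core of compound 3 differs from that of compound 2 is not broken down here. Compound 4 `O=C(Nc1ccc([N+](=O)[O-])c(Cl)c1)c1cc(Br)ccc1O` has not yet been measured. It arises from compound 3 by the same kind of change, (nitro in place of trifluoromethyl on an aromatic carbon), though here the place is also ortho to a chloro group (1 heavy atom). Because the earlier step was an at least 6.4-fold higher number from compound 2 to compound 1 (0.80 log units; beyond the scatter), a step of an at least 2.5-fold higher number from compound 3 to compound 4 (0.39 log units; beyond the scatter) is expected here. Compound 4 is therefore estimated at 2.5 ug/mL, between 0.6 ug/mL and 10 ug/mL.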

Compound 4, solubility: < 1 ug/mL
Compound 4 gave a limit, no number; the forecaster's own chance of this, stated with the estimate: 35%; at least 2.5-fold (0.39 log units) between middle value and limit.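

In this assay, among these compounds, compound 3 and compound 4 sit at the same limit, so no step between them can be read: the limit of < 1 ug/mL in this assay, at which 3 of the 4 values shown sit. The compounds shown leave open whether nitro in place of trifluoromethyl changes the read-out on this core at all.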